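Sugar-linked azole thioethers: expected growth inhibition of compound 4

This account rests on a few compounds, and the source may have more. Where it says the series, first, only, none or still open, it means among the compounds named here.

Measured in a functional assay on A549 cells (Homo sapiens) for antiproliferative activity, read by sulforhodamine B assay, with a stated time of 48 h; on this read-out lower numbers stand for stronger inhibition of growth and higher numbers for weaker inhibition of growth:
compound 1 `COc1cc(C2=NOC(CO[C@@H]3O[C@H](CSc4ncn[nH]4)[C@H]4OC5(CCCC5)O[C@@H]34)C2)cc(OC)c1OC` gives 37000 nM
compound 2 `Cc1ccc(S(=O)(=O)OC[C@H]2O[C@@H](OCc3noc(-c4ccc([N+](=O)[O-])cc4)n3)[C@@H]3OC4(CCCC4)O[C@@H]32)cc1` gives only a limit, > 100000 nM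
compound 3 `Clc1ccc(-c2nc(CO[C@@H]3O[C@H](CSc4ncn[nH]4)[C@H]4OC5(CCCC5)O[C@@H]34)no2)cc1` gives 13000 nM

Compound 2 stands apart: its result is a limit of the assay and not a number, the same (the limit of > 100000 nM in this assay, at which 1 of the 3 values shown sits), so it gives nothing to compare directly. Compound 4 `Nc1nnc(SC[C@H]2O[C@@H](OCc3noc(-c4ccc([N+](=O)[O-])cc4)n3)[C@@H]3OC4(CCCC4)O[C@@H]32)s1` is not yet measured and differs from compound 2 at one place: (5-amino-1,3,4-thiadiazol-2-yl)sulfanyl in place of ((4-methylphenyl)sulfonyl)oxy on a saturated chain carbon bound to a saturated ring carbon. Among the measured compounds shown here, no measured pair covers this change. Because compound 1 gives 37000 nM and compound 3 gives 13000 nM, both lacking the ((4-methylphenyl)sulfonyl)oxy group, the step of an at least 3.3-fold lower number from compound 2 to compound 4 (0.52 log units; beyond the scatter) is expected to move toward stronger inhibition of growth. Compound 4 is estimated at 30000 nM, with a range from 8000 nM to 150000 nM.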

Compound 4, concentration for 50% growth inhibition: 14000 nM
Compound 4: the middle estimate sits 2.1-fold (0.33 log units) above what was measured; measured number inside the range.
By their numbers in this assay, from the lowest: compounds 3 and 4 (each within the scatter of the next); then compound 1. At a limit, above all of these: compound 2.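

In this assay, (5-amino-1,3,4-thiadiazol-2-yl)sulfanyl in place of ((4-methylphenyl)sulfonyl)oxy on a saturated chain carbon bound to a saturated ring carbon gives an at least 7.1-fold lower number from compound 2 to compound 4 (0.85 log units; beyond the scatter). The result for compound 2 is a limit of the assay and not a number: the limit of > 100000 nM in this assay, at which 1 of the 4 values shown sits.

Growth inhibition thus responds to the group at this position, with compound 4 giving 14000 nM, though the full size of the step cannot be read.

Still open, going by these compounds, is how a free hydroxyl or a simple amine would read at this position. Also open, on these data alone, is whether the thiadiazole keeps this level without its amino group.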